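Trimethoxyphenyl Pyrazolo Series: From Acetylphenyl to Cyanophenyl

This account rests on a few compounds, and the source may have more. Where it says the series, first, only, none or still open, it means among the compounds named here.

Three compounds sharing a trimethoxyphenyl group on a fused core have been measured in a functional assay on B16-F0 cells (Mus musculus) for inhibition, read by CCK-8 assay, with a stated time of 48 h; on this read-out higher numbers stand for weaker inhibition and lower numbers for stronger inhibition. Compound 1 `COc1cc(-c2ccnc3c(-c4ccc(C)cc4)cnn23)cc(OC)c1OC` carries a methylphenyl group. In this assay compound 1 reaches only a limit, > 10000 nM. Compound 3 `COc1cc(-c2cc3nccc(-c4c[nH]c5ccccc45)n3n2)cc(OC)c1OC` carries an indolyl group. In this assay compound 3 likewise reaches only a limit, > 10000 nM. For the measured compounds named here, compound 2 `COc1cc(-c2ccnc3cc(-c4ccc(C(C)=O)cc4)nn23)cc(OC)c1OC` carries a 4-acetylphenyl group, and in this assay compound 2 gives 3930 nM, the only value that is a number, because of the limit of > 10000 nM in this assay, at which 2 of the 3 values shown sit. Going by the values given here, compound 2 thus stands alone as the one member of the set with a measured inhibitory concentration.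

Compound 4 `COc1cc(-c2ccnc3cc(-c4cccc(C#N)c4)nn23)cc(OC)c1OC` is the next compound, not yet measured. It differs from compound 2 in one place: 3-cyanophenyl in place of 4-acetylphenyl on an aromatic carbon. The exchange keeps the ring size and the count of hydrogen-bond acceptors, while the double bond outside the ring gives way to a triple bond. Among the compounds with values here, no step between measured compounds shows how such an exchange behaves here, so the expectation rests on compound 2 alone. The step expected is a 1.3-fold higher number from compound 2 to compound 4 (0.10 log units; within the scatter), which lies within the usual scatter. Compound 4 is therefore estimated at 5000 nM, in a range from 2000 nM to 12500 nM.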

Compound 4, half-maximal inhibitory concentration: > 10000 nM
Compound 4: no number, only a limit; the forecaster's own chance of this, stated with the estimate: 35%; middle value at least 2.0-fold (0.30 log units) away from the limit.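

In this assay, for the compounds shown here, the exchange of 4-acetylphenyl for 3-cyanophenyl on an aromatic carbon of the five-membered aromatic ring gives an at least 2.5-fold higher number from compound 2 to compound 4 (0.40 log units; beyond the scatter), the first step that can be read, and it lies beyond the scatter. Compound 4 gives > 10000 nM, which is a limit of the assay and not a number, so the step has a lower bound but no known size. Compound 2 remains the only compound in the set with a number, even though the exchange leaves the count of hydrogen-bond acceptors unchanged, and compound 4 now joins the others at the limit: the limit of > 10000 nM in this assay, at which 3 of the 4 values shown sit.

The single exchange replaces the acetyl group with a nitrile and also changes the group's name from a 4-substituted to a 3-substituted phenyl, and the compounds shown cannot separate these two changes; 4-cyanophenyl or 3-acetylphenyl on the same carbon would do so. From the compounds shown here alone, it also remains open whether a different group there, such as 4-aminophenyl or 4-carboxyphenyl, would give a lower number than compound 2.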